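The source may hold more compounds than are shown below. What is called first, only, known or untested is meant among the compounds shown, and "the series" means these compounds.

In an ADME assay on Akata cells (Homo sapiens) for cytotoxicity, with a stated time of 7 days; a lower number here means that less compound is tolerated, a higher number that more compound is tolerated:
- Compound 1 `Nc1nc(NCc2ccccc2)c2ncn(/C=C3/CC3(CO)CO)c2n1`: > 24000 nM (a limit)
- Compound 2 `Nc1nc(SC2CCCC2)c2ncn(/C=C3/CC3(CO)CO)c2n1`: > 20000 nM (a limit)

Compound 2 has no numerical value, only the limit of > 20000 nM. The other value in the series, for compound 1, is also a limit, so the two compounds cannot be ranked. The next compound to read is compound 3 `CCCCOc1nc(N)nc2c1ncn2/C=C1/CC1(CO)CO`, which carries butoxy in place of cyclopentylsulfanyl on an aromatic carbon. Within the data shown here, the only measured step that bears on this change is a step that the two limits leave unreadable from compound 1 to compound 2. It involves the same aromatic carbon, but no size can be carried over from it. The expectation therefore rests mainly on the limit of compound 2, > 20000 nM. No step beyond the scatter is expected in this assay, and a further limit is the most likely report. The expected change is a step that the limit leaves unreadable from compound 2 to compound 3, an estimate that stays within the scatter. For compound 3 the estimated value is 22000 nM, with an expected range of 7000 nM to 70000 nM.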

Compound 3, half-maximal cytotoxic concentration: > 20000 nM
Compound 3 was reported as a limit; the forecaster's own chance of this, stated with the estimate: 70%; the middle value lies beyond the limit too.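

In this assay, among these compounds, compound 1, compound 2 and compound 3 are all reported as limits, so no step between any two of them can be read. The compounds shown leave open whether benzylamino, cyclopentylsulfanyl or butoxy on that aromatic carbon changes the half-maximal cytotoxic concentration at all, and by how much.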